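A few compounds are considered here, and "the series" means these few. Any claim that something is new, unique, unknown or untested is made for them only; others in the source may bear on it.

In an assay on CHO cells with metabotropic glutamate receptor 2 (Homo sapiens) as the target, read by FLIPR (a higher number here means a larger maximal response, a lower number a smaller maximal response), the three measured compounds give: compound 1 `Cn1c(CN2CCN(c3ccc(Cl)cc3F)CC2)nc2ccccc21`, 69%; compound 2 `Cn1c(CN2CCN(c3ccccc3F)CC2)nc2ccccc21`, 64%; compound 3 `Cn1c(CN2CCN(c3ccccn3)CC2)nc2ccccc21`, 100%.

Compound 2 has the lowest number of the three. Its nearest neighbour is compound 1, and the step of a number 5 percentage points lower from compound 1 to compound 2 (within the scatter) lies within the scatter, so compounds 1 and 2 cannot be told apart. Compound 3 is furthest off: the step of a number 36 percentage points higher from compound 2 to compound 3 (beyond the scatter) is large, as is a number 31 percentage points higher from compound 1 to compound 3 (beyond the scatter).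

Compound 4 `Cn1c(CN2CCN(c3ccccc3C(F)(F)F)CC2)nc2ccccc21` differs from compound 2 in one place: trifluoromethyl in place of fluoro on an aromatic carbon.

Within the data shown here, the only measured step that touches the same ring is a number 5 percentage points lower from compound 1 to compound 2 (within the scatter), a swap of one halogen for hydrogen, and it stayed within the scatter. The large steps both replace the whole ring with pyridin-2-yl and do not speak to a change of one group on the carbon ring. On this basis no step beyond the scatter is expected for a number 1 percentage points lower from compound 2 to compound 4 (within the scatter).

Compound 4 is therefore estimated at 63% in this assay, with a range from 45% to 82%.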

Compound 4, largest response reached (Emax), in percent of the reference or control that the assay uses: 84%
Compound 4: the middle estimate sits 21 percentage points below what was measured; measured number outside the range, above it.
By their numbers in this assay, from the lowest: compounds 2 and 1 (each within the scatter of the next); then compound 4; then compound 3.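

The carbon of the six-membered aromatic ring that is ortho to a large group responds to the exchange of its substituent: in this assay, the change to trifluoromethyl gives a number 20 percentage points higher from compound 2 to compound 4 (beyond the scatter), a modest step. Among these compounds, until now the only change on this carbon ring, a number 5 percentage points lower from compound 1 to compound 2 (within the scatter), stayed within the scatter, and only replacing the whole ring with pyridin-2-yl had moved the number beyond it; a single group on the carbon ring can therefore do so too. Nothing available bears on the reason for this step.

Still open, from the compounds shown here alone, is how a methyl, a methoxy or a nitrile on the same carbon would compare with fluoro and trifluoromethyl. Also open, going by these compounds, is whether trifluoromethyl would give a step of similar size on the pyridin-2-yl ring of compound 3.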